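Aryl swap on the aromatic nitrogen of a weak series

The source may report more compounds than this note shows. Statements on the series, on what has been measured and on what is new or still open speak of the compounds shown alone.

Compound 3 `CCOc1ccccc1-n1nncc1CN1C(=O)C2(C(C#N)=C(N)Oc3c(N)cc4nc5ccccc5nc4c32)c2ccccc21` stands only as a limit in an ADME assay on HUVEC cells (Homo sapiens) for antiproliferative activity, read by MTT assay, with a stated time of 48 h; on this read-out lower numbers stand for stronger inhibition and higher numbers for weaker inhibition: compound 3 gives > 50000 nM. Compound 2 `N#CC1=C(N)Oc2c(N)cc3nc4ccccc4nc3c2C12C(=O)N(Cc1cnnn1-c1cccc(C(F)(F)F)c1)c1ccccc12` is likewise a limit, and in this assay compound 2 gives > 50000 nM. Among the measured compounds shown here, compound 1 `N#CC1=C(N)Oc2c(N)cc3nc4ccccc4nc3c2C12C(=O)N(Cc1cnnn1-c1ccccc1Br)c1ccccc12` is the one number actually read; in this assay compound 1 gives 34200 nM. The measured steps that bear on the aryl group on the aromatic nitrogen are an at least 1.4-fold higher number from compound 1 to compound 3 (0.16 log units; that floor lies within the scatter) and a step that the two limits leave unreadable from compound 2 to compound 3, and the limit of > 50000 nM in this assay, at which 2 of the 3 values shown sit, shows how little room these data leave. Compound 4 `Cc1cc(C)cc(-n2nncc2CN2C(=O)C3(C(C#N)=C(N)Oc4c(N)cc5nc6ccccc6nc5c43)c3ccccc32)c1` differs from compound 3 by 3,5-dimethylphenyl in place of 2-ethoxyphenyl on an aromatic nitrogen. With both other aryl variants sitting at the limit, compound 4 is expected to show no step beyond the scatter, a step that the limit leaves unreadable from compound 3 to compound 4, and its value is estimated at 55000 nM with a range of 30000 nM to 120000 nM.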

Compound 4, half-maximal inhibitory concentration: > 50000 nM
Compound 4: no number, only a limit; the forecaster's own chance of this, stated with the estimate: 70%; the middle value is on the limit's open side.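

In this assay compound 4 gives > 50000 nM, which is a limit of the assay and not a number. Among the compounds shown here, a third aryl group, 3,5-dimethylphenyl, which has no oxygen and no hydrogen-bond acceptor, therefore also gives no readable number at this position; the steps from compound 2 and from compound 3 to compound 4 cannot be read, and the one step with a floor is an at least 1.4-fold higher number from compound 1 to compound 4 (0.16 log units; that floor lies within the scatter). The ceiling now covers most of this small set: the limit of > 50000 nM in this assay, at which 3 of the 4 values shown sit.

As far as these compounds go, it remains open whether a phenyl group carrying an amine or a carboxylic acid on this nitrogen would give a readable number. The compounds shown also leave open how a 2-chlorophenyl group would compare with the 2-bromophenyl group of compound 1.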